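The compounds below may be only part of what the source reports. "The series", "measured", "known", "first", "only" and "open" are said of these compounds alone.

Compound 1, `COc1cc2c(/C=C3/C(=O)Nc4ccc(Cl)cc43)c(Cl)n(Cc3cc(OC)c(OC)c(OC)c3)c2cc1C`, was measured in a functional assay on NSCLC cells (Homo sapiens) for cytotoxicity, with a stated time of 48 h (a higher number here means a weaker inhibitor of growth, a lower number a stronger inhibitor of growth), and in that assay compound 1 gives 5890 nM. Among the measured compounds shown here, its only measured companion is compound 2, `COc1cc2c(/C=C3/C(=O)Nc4cccc(Cl)c43)c(Cl)n(Cc3cc(OC)c(OC)c(OC)c3)c2cc1C`, which in this assay gives 12000 nM; the two differ in one place, and the step runs a 2.0-fold higher number from compound 1 to compound 2 (0.31 log units; beyond the scatter). On these two numbers compound 1 stands as the lower of the pair, meaning the stronger inhibitor of growth among them.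

Compound 3, `COc1ccc2c(c1)/C(=C\c1c(Cl)n(Cc3cc(OC)c(OC)c(OC)c3)c3cc(C)c(OC)cc13)C(=O)N2`, departs from compound 1 by a different route: methoxy in place of chloro on an aromatic carbon. For the measured compounds named here, no measured step in this small set touches the same kind of change; the one step known, a 2.0-fold higher number from compound 1 to compound 2 (0.31 log units; beyond the scatter), concerns another part of the molecule and shows only that modest shifts occur. Going by the values given here, with no direct precedent, the step in this assay is expected to be a 1.2-fold higher number from compound 1 to compound 3 (0.07 log units; within the scatter), a change not expected to go beyond the scatter in either direction. Compound 3 is therefore estimated at 7000 nM, with a likely range from 2500 nM to 20000 nM.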

Compound 3, concentration for total growth inhibition: 97700 nM
For compound 3 the middle estimate is 14-fold (1.14 log units) below the measured one; measured number outside the range, above it.
By their numbers in this assay, from the lowest: compound 1; then compound 2; then compound 3.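

In this assay, replacing the chloro of compound 1 with methoxy gives a large change (a 17-fold higher number from compound 1 to compound 3 (1.22 log units; beyond the scatter)), which shows that this aromatic carbon, meta to a fused ring and para to a fused ring, is far from indifferent to the group it carries. Among the compounds shown here, the only earlier step (a 2.0-fold higher number from compound 1 to compound 2 (0.31 log units; beyond the scatter)) was modest, so this series can respond much more sharply than that pair suggested, and exchanging a single chloro for a methoxy is enough to weaken growth inhibition this strongly. Nothing available here explains the size of this drop.

The compounds shown put only chloro and methoxy as substituents on this carbon, so it remains open whether the weakening is particular to methoxy or would follow from other replacements of chloro, such as fluoro, methyl, an amine or a carboxylic acid. It is also unknown whether a methoxy in place of the chloro of compound 2 would produce a similarly large change.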